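A few compounds are considered here, and "the series" means these few. Any claim that something is new, unique, unknown or untested is made for them only; others in the source may bear on it.

Compound 1, with the structure `Cc1ccccc1/N=C1\NC(=O)/C(=C\c2ccc(N(C)C)cc2)S1`, is the stronger of the two compounds measured in a functional assay on NCI-H460 cells (Homo sapiens) for antiproliferative activity (a lower number here means a stronger inhibitor, a higher number a weaker inhibitor), where compound 1 gives 540 nM. Among the measured compounds shown here, its only measured neighbour is compound 2, the structure `CN(C)c1ccc(/C=C2/S/C(=N/c3ccc(Cl)cc3)NC2=O)cc1`, for which this assay returns 2930 nM; the step of a 5.4-fold higher number from compound 1 to compound 2 (0.73 log units; beyond the scatter) comes from a change on the double-bonded nitrogen, where a 4-chlorophenyl replaces the 2-methylphenyl of compound 1.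

Compound 3, the structure `COc1ccc(/C=C2/S/C(=N/c3ccccc3C)NC2=O)cc1`, keeps the 2-methylphenyl of compound 1 and differs elsewhere: methoxy in place of dimethylamino on an aromatic carbon, at a place para to a large group. For the measured compounds named here, no measured step touches this part of the core of compound 1, so the single known step from compound 1 to compound 2 gives no direct guide for the direction or size of the change to compound 3. The one firm point is the value of compound 1 in this assay, 540 nM, from which the estimate has to start.

On that basis a modest weakening, a 2.2-fold higher number from compound 1 to compound 3 (0.35 log units; beyond the scatter), is expected, and compound 3 is estimated at 1200 nM, within a range from 400 nM to 4000 nM.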

Compound 3, half-maximal inhibitory concentration: 1700 nM
Compound 3: middle estimate off by 1.4-fold (0.15 log units), on the low side; measured number inside the range.
By their numbers in this assay, from the lowest: compound 1; then compounds 3 and 2 (each within the scatter of the next).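

In this assay, replacing dimethylamino with methoxy on the aromatic carbon, para to a large group, brings a 3.1-fold higher number from compound 1 to compound 3 (0.50 log units; beyond the scatter) and so shows that this part of the molecule, untouched by the earlier step, also affects the antiproliferative read-out. With the 2-methylphenyl group held constant, the change removes dimethylamino, with its 3 heavy atoms, and introduces methoxy, with 2, while the hydrogen-bond donor and acceptor counts and the absence of net charge stay the same, so these counts do not distinguish the two groups. No measurement at hand explains why the number rises at this position.

The compounds shown leave open how a primary amine, a hydroxyl group or a longer chain such as diethylamino or ethoxy would behave at this same aromatic carbon, since one replacement cannot show which feature of the group matters. They also leave open whether methoxy would produce a similar step when paired with the 4-chlorophenyl group on the double-bonded nitrogen, which would test whether the two changes act independently.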